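The source may report more compounds than this note shows. Statements on the series, on what has been measured and on what is new or still open speak of the compounds shown alone.

Of the compounds shown here, three that share a common core have been tested in a functional assay on PC-12 cells (Rattus norvegicus) for cytotoxicity, read by MTT assay, with stated times of 3 h and 2 h, tested at 50 uM; a higher number here means a stronger effect of the compound at the concentration tested, a lower number a weaker effect. Compound 1 `O=C(CCCCC1CCSS1)NCc1cn(CCCOc2ccc3cc(-c4ccccc4)c(=O)oc3c2)nn1` gives 23.1% in that assay. Compound 2 `COc1ccc(-c2cc3ccc(OCCCn4cc(CNC(=O)CCCCC5CCSS5)nn4)cc3oc2=O)cc1` gives 65.7%. Going by the values given here, the only change between these two is methoxy in place of hydrogen on an aromatic carbon, and it produced a step of a number 42.6 percentage points higher from compound 1 to compound 2 (beyond the scatter). Compound 3 `COc1ccc(-c2cc3ccc(OCCCCCn4cc(CNC(=O)CCCCC5CCSS5)nn4)cc3oc2=O)cc1` gives 52.8%; how its core differs from the core of compound 1 is not broken down here. Its number stands between the other two, beyond the scatter on both sides.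

Compound 4 `COc1ccc(-c2cc3ccc(OCCCCCn4cc(CNC(=O)CCCCC5CCSS5)nn4)cc3oc2=O)cc1OC` has not yet been measured. It differs from compound 3 by methoxy in place of hydrogen on an aromatic carbon. Among the compounds with values here, this is the same kind of change as the one from compound 1 to compound 2, but not the same: in the earlier pair the new group sits para to a large group, whereas in compound 4 it sits ortho to a methoxy group and meta to a large group. A rise is expected for compound 4 in this assay because a number 42.6 percentage points higher from compound 1 to compound 2 (beyond the scatter) shows the same kind of change lifting the number well beyond the scatter. Since the surroundings of the new group are not identical, a smaller step of a number 12.2 percentage points higher from compound 3 to compound 4 (beyond the scatter) is expected rather than a copy of the earlier one. Compound 4 is therefore estimated to give 65% in this assay, with a likely range from 45% to 85%.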

Compound 4, a percentage reported as activity, at one concentration (the size of the read-out at that concentration, not a potency): 55%
Compound 4: middle estimate off by 10 percentage points, on the high side, within the range that was stated.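

In this assay, turning 4-methoxyphenyl into 3,4-dimethoxyphenyl gave a number 2.2 percentage points higher from compound 3 to compound 4 (within the scatter), so the added methoxy cannot be said to have changed the read-out on this core. Going by these compounds alone, the same kind of swap, hydrogen to methoxy on an aromatic carbon, therefore did not carry over with the same size from one core to the other: the same change on two cores in this assay, a number 42.6 percentage points higher (beyond the scatter) from compound 1 to compound 2 and a number 2.2 percentage points higher (within the scatter) from compound 3 to compound 4, 40.4 percentage points apart, beyond the scatter of two such steps This does not show that the change is inactive in general or that one core is what sets the size of the step, since these are only two pairs, and they differ both in the core and in the surroundings of the new methoxy, which here sits ortho to a methoxy group and meta to a large group, so the data cannot separate those factors.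

The compounds shown leave open what the 3,4-dimethoxyphenyl group would do on the core of compound 2, which would help to separate the effect of the core from that of the surroundings. They also leave open whether a hydroxyl group, a fluorine or an amine in the place of the new methoxy would give a different number from the methoxy in compound 4.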